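Working notes on a T-type channel series

The source may hold more compounds than are shown below. What is called first, only, known or untested is meant among the compounds shown, and "the series" means these compounds.

Measured so far:
compound 1 `O=C(CC1c2ccccc2N=C(c2ccccc2)N1c1ccccc1)OCc1ccccc1` gives 14.2%
compound 2 `O=C(CC1c2ccccc2N=C(N2CCCCC2)N1c1ccccc1)OCc1ccccc1` gives 15.6%

In a functional assay on cells (Oocyte) for inhibition of Voltage-dependent T-type calcium channel subunit alpha-1H (Homo sapiens), tested at 100 uM (a lower number here means less inhibition, a higher number more inhibition at the concentration tested (going by the name of the read-out)), compound 2 stands highest of the two numbers, with compound 1 as its nearest neighbour. Among the measured compounds shown here, the one measured step, a number 1.4 percentage points higher from compound 1 to compound 2 (within the scatter), lies within the scatter, so the two values cannot be ordered.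

The next compound is compound 3 `CN1CCN(C2=Nc3ccccc3C(CC(=O)OCc3ccccc3)N2c2ccccc2)CC1`. It differs from compound 2 in one place: 4-methylpiperazin-1-yl in place of piperidin-1-yl on a carbon with a double bond to nitrogen. For the measured compounds named here, the only step that bears on this change is a number 1.4 percentage points higher from compound 1 to compound 2 (within the scatter), in which a phenyl group on the same carbon with a double bond to nitrogen was exchanged for piperidin-1-yl without moving the read-out beyond the scatter. On that basis the present exchange of one cyclic amine for another at the same position is expected to give a step of a number 0.4 percentage points higher from compound 2 to compound 3 (within the scatter), none beyond the scatter. The expected value for compound 3 is therefore 16%, with a range from 4% to 30%. Going by the values given here, only one step supports this expectation.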

Compound 3, a percentage reported as inhibition, at one concentration (the size of the read-out at that concentration, not a potency): 32.7%
Beside the measured number, compound 3's estimate is 16.7 percentage points below it; measured number outside the range, above it.
By their numbers in this assay, from the lowest: compounds 1 and 2 (each within the scatter of the next); then compound 3.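

In this assay, the substituent on the carbon with a double bond to nitrogen can move the read-out beyond the scatter: the exchange of piperidin-1-yl for 4-methylpiperazin-1-yl gives a number 17.1 percentage points higher from compound 2 to compound 3 (beyond the scatter), and that of phenyl for the same group gives a number 18.5 percentage points higher from compound 1 to compound 3 (beyond the scatter). The earlier exchange of phenyl for piperidin-1-yl gave only a number 1.4 percentage points higher from compound 1 to compound 2 (within the scatter), so a cyclic amine at this carbon does not by itself separate the compounds; among the two six-membered amine rings, the one with 2 hetero atoms, in compound 3, stands apart from the one with 1 hetero atom, in compound 2. No data on hand explain this step.

The compounds shown leave open whether the step follows the second ring nitrogen or its methyl group, a question that a piperazin-1-yl ring with a free amine hydrogen or a morpholin-4-yl ring at the same carbon would address. They also leave open whether the step holds when the shared groups change, for example with a carboxylic acid in place of the benzyl ester.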